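A few compounds are considered here, and "the series" means these few. Any claim that something is new, unique, unknown or untested is made for them only; others in the source may bear on it.

Of the compounds shown here, two have been measured so far in a functional assay on HL-60 cells (Homo sapiens) for inhibition, read by CCK-8 assay, with a stated time of 48 h (a lower number here means a stronger inhibitor, a higher number a weaker inhibitor), and they sit close together. Compound 2 `COc1ccc(S(=O)(=O)Oc2ccccc2/C=C(\C#N)C(=O)Nc2nnc(Cc3ccc(F)cc3)s2)cc1` stands at 4050 nM and compound 1 `COc1ccc(Cc2nnc(NC(=O)/C(C#N)=C/c3ccccc3OS(=O)(=O)c3ccc(OC)cc3)s2)cc1` at 3120 nM with a gap that lies within the scatter of repeated measurements, so these two numbers cannot rank them.

Compound 3 `COc1ccc(S(=O)(=O)Oc2ccccc2/C=C(\C#N)C(=O)Nc2nnc(Cc3cccc(F)c3)s2)cc1` has not been measured yet. It differs from compound 2 in one group (3-fluorophenyl in place of 4-fluorophenyl on a saturated chain carbon bound to an aromatic carbon) and the two have the same atoms, joined differently: 3-fluorophenyl in place of 4-fluorophenyl on a saturated chain carbon bound to an aromatic carbon.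

Among the compounds with values here, no measured pair yet shows what exchanging these two fluorophenyl groups does. Within the data shown here, the only measured step that bears on it, and only indirectly, is a 1.3-fold higher number from compound 1 to compound 2 (0.11 log units; within the scatter) for fluoro in place of methoxy on an aromatic carbon. With that step within the scatter, no step beyond the scatter is expected for compound 3 in this assay on this evidence. The expected step is a 1.1-fold lower number from compound 2 to compound 3 (0.03 log units; within the scatter) in size. Compound 3 is estimated at 3800 nM (expected range 1900 nM to 7500 nM).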

Compound 3, half-maximal inhibitory concentration: 3880 nM
The estimate for compound 3 lay 1.0-fold (0.01 log units) below the measured number, and the stated range covers the measured number.
By their numbers in this assay, from the lowest: compounds 1, 3 and 2 (each within the scatter of the next).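

In this assay, within the data shown here, exchanging 4-fluorophenyl for 3-fluorophenyl on a saturated chain carbon bound to an aromatic carbon gives a 1.0-fold lower number from compound 2 to compound 3 (0.02 log units; within the scatter) and is the first direct look at this exchange, which produces no difference that can be told apart from assay noise. The comparison with the methoxy-bearing compound gives a 1.2-fold higher number from compound 1 to compound 3 (0.09 log units; within the scatter) in the same assay, so 4-methoxyphenyl, 4-fluorophenyl and 3-fluorophenyl cannot be ranked at this place, and none of the three compounds goes against that reading. No measurement is available here that could explain why these exchanges leave the number so little changed.

Going by these compounds, all three compounds carry a singly substituted phenyl ring at this place, so it remains open whether a very different group, such as a carboxylic acid or a dimethylamino group on that ring, or a longer chain in place of the single saturated carbon, would move the number beyond the scatter. Whether the three compounds also stay together outside this assay is open as well, as no other read-out appears here.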